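The source may report more compounds than this note shows. Statements on the series, on what has been measured and on what is new or still open speak of the compounds shown alone.

Of the compounds shown here, two have already been measured in an assay on CHO cells for displacement of a labelled ligand from prostaglandin E2 receptor EP1 subtype (Homo sapiens); a higher number here means a weaker inhibitor, a lower number a stronger inhibitor. Compound 1, with structure `COc1ccc(Cc2nnc(CN(c3cccc(C(F)(F)F)c3C)S(=O)(=O)c3ccc(C)cc3)o2)cc1`, gives 63.1 nM in this assay. Compound 2, with structure `Cc1ccc(S(=O)(=O)N(Cc2nnc(Cc3ccc(F)cc3)o2)c2cccc(Cl)c2C)cc1`, gives 200 nM in this assay, which is the higher of the two numbers, and its gap to compound 1 is beyond the scatter, so compound 2 is the weaker inhibitor of the pair. Compound 3, with structure `Cc1ccc(S(=O)(=O)N(Cc2nnc(Cc3ccc(Cl)cc3Cl)o2)c2cccc(Cl)c2C)cc1`, has not yet been measured. It differs from compound 2 in one place: 2,4-dichlorophenyl in place of 4-fluorophenyl on a saturated chain carbon bound to an aromatic carbon. Within the data shown here, no measured pair shows this same change, so its effect can only be guessed. The step from compound 2 to compound 3 is expected to be small, with no clear direction, as a 1.4-fold lower number from compound 2 to compound 3 (0.15 log units; within the scatter). Compound 3 is therefore estimated to give 140 nM in this assay, with a range from 40 nM to 450 nM.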

Compound 3, half-maximal inhibitory concentration: 63.1 nM
The estimate for compound 3 lay 2.2-fold (0.35 log units) above the measured number, within the range that was stated.
By their numbers in this assay, from the lowest: compounds 1 and 3 (each within the scatter of the next); then compound 2.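

The group on the saturated chain carbon clearly matters for binding: in this assay, 2,4-dichlorophenyl in place of 4-fluorophenyl gives a modest gain (a 3.2-fold lower number from compound 2 to compound 3 (0.50 log units; beyond the scatter)). Among these compounds, this is the only comparison so far that isolates this group, since compound 1 and compound 2 differ in more than one place. Nothing measured here explains why the number falls.

Among the compounds shown here, with only one pair, the effect of adding two chlorine atoms cannot be separated from that of removing the fluorine, and a ring carrying a single chlorine or a plain phenyl ring could help to separate them. From the compounds shown here alone, it also remains open how this position would respond to quite different groups, such as an amine, a carboxylic acid or a longer chain.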